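Capping the phenolic oxygen of compound 3 with cyclopropylmethyl

This account rests on a few compounds, and the source may have more. Where it says the series, first, only, none or still open, it means among the compounds named here.

Compound 3, `CCOC(=O)c1cnc(-c2ccccc2O)[nH]c1=O`, carries an ethyl ester on the shared core, whereas compound 1, `O=C(O)c1cnc(-c2ccccc2O)[nH]c1=O`, carries the free acid, and compound 2, `CCOc1ccc(S(=O)(=O)N(C)C(C)C)cc1-c1ncc(C(=O)O)c(=O)[nH]1`, differs in more than one place. In a functional assay on the whole organism (strain Sprague-Dawley) for inhibition, with Rattus norvegicus as the target, with a stated time of 10 min (a lower number here means that less compound is needed, a higher number that more compound is needed for the effect), compound 3 gives 5 mg/kg. Compound 1 gives > 5 mg/kg, which is a limit of the assay and not a number. Compound 2 gives > 10 mg/kg, again a limit rather than a number. Among the compounds with values here, compound 3 therefore stands as the only measured number among the three, the other two values sitting at the limit of > 5 mg/kg in this assay, at which 1 of the 3 values shown sits, and at the limit of > 10 mg/kg in this assay, at which 1 of the 3 values shown sits. Within the data shown here, the single readable step, a number no higher from compound 1 to compound 3 (the limit leaves the size open), leaves its size open.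

Compound 4, `CCOC(=O)c1cnc(-c2ccccc2OCC2CC2)[nH]c1=O`, differs from compound 3 in one place: cyclopropylmethyl in place of hydrogen on an oxygen on an aromatic ring. No measured step touches this oxygen, and the one step shown, a number no higher from compound 1 to compound 3 (the limit leaves the size open), concerns another part of the molecule and is itself of unreadable size. There is thus no ground to expect a shift beyond the scatter in this assay in either direction. Compound 4 is estimated to give 5 mg/kg, between 1.5 mg/kg and 15 mg/kg, so that the step of no change at the digits printed from compound 3 to compound 4 (within the scatter) is expected to remain within the scatter.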

Compound 4, dose for 50% inhibition: 0.3 mg/kg
Beside the measured number, compound 4's estimate is 17-fold (1.22 log units) above it, and the stated range ends above it.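

In this assay, putting cyclopropylmethyl on the oxygen on the aromatic ring gives a 17-fold lower number from compound 3 to compound 4 (1.22 log units; beyond the scatter) and is the only change shown whose size can be read, since the step from compound 1 to compound 3 ends in a limit. It shows that this oxygen is a place where one change, hydroxy to cyclopropylmethoxy with the ethyl ester kept, can greatly reduce the dose needed for the effect. Nothing measured here bears on why the number falls.

The compounds shown carry only cyclopropylmethyl in the ester series, so they leave open whether a methyl, a longer chain or a chain ending in an amine would do the same. They also leave open whether this group lowers the number when the core carries the carboxylic acid of compound 1 instead of the ethyl ester.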